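The compounds below may be only part of what the source reports. "The series", "measured", "known", "first", "only" and "open" are said of these compounds alone.

Measured compounds:
compound 1 `CS/C(=N\C(=O)c1cc(-c2ccccc2)nc2ccccc12)NC(=O)c1cc(-c2ccccc2)nc2ccccc12` — > 100000 nM
compound 2 `CS/C(=N\C(=O)c1csc([N+](=O)[O-])c1)NC(=O)c1csc([N+](=O)[O-])c1` — 82500 nM

In a functional assay on PC-3 cells (Homo sapiens) for cytotoxicity, read by MTT assay, with a stated time of 72 h (on this read-out higher numbers stand for weaker inhibition of growth and lower numbers for stronger inhibition of growth), compound 1 gives > 100000 nM, which is a limit of the assay and not a number. In this assay compound 2 gives 82500 nM. Compound 1 stands at the limit of > 100000 nM in this assay, at which 1 of the 2 values shown sits. Compound 3 `C[Se]/C(=N\C(=O)c1cc(-c2ccccc2)nc2ccccc12)NC(=O)c1cc(-c2ccccc2)nc2ccccc12` differs from compound 1 by a group of 2 heavy atoms (1 carbon, 1 selenium; no ring) in place of a group of 2 heavy atoms (1 carbon, 1 sulfur; no ring), on a carbon with a double bond to nitrogen. Among the compounds with values here, no measured pair shows this kind of change, and the step from compound 1 to compound 3 in this assay is expected to stay within the scatter, in no clear direction. Compound 3 is therefore estimated at 100000 nM, expected between 30000 nM and 300000 nM. That estimate means a number no higher from compound 1 to compound 3 (the limit leaves the size open).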

Compound 3, concentration for total growth inhibition: 40200 nM
The estimate for compound 3 lay 2.5-fold (0.40 log units) above the measured number; the measured number falls inside the stated range.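

In this assay, replacing methylsulfanyl with the group of carbon and selenium, on a carbon with a double bond to nitrogen, gives an at least 2.4-fold lower number from compound 1 to compound 3 (0.39 log units; beyond the scatter) beyond the scatter. Within the data shown here, this is the first sign that the number at this place can shift when sulfur gives way to selenium. The value of compound 1 is a limit of the assay and not a number, leaving the full size of the step open: the limit of > 100000 nM in this assay, at which 1 of the 3 values shown sits.

From the compounds shown here alone, whether the same change lowers the number on the core of compound 2 stays open. Also open, going by these compounds, is how an amine or a longer chain at this place would read.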